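The compounds below may be only part of what the source reports. "The series", "measured", "known", "first", "only" and "open" are said of these compounds alone.

Measured so far:
compound 1 `NS(=O)(=O)Cc1noc2ccc(Br)cc12`: 14 mg/kg
compound 2 `CCNS(=O)(=O)Cc1noc2ccc(Br)cc12`: 18 mg/kg

Both numbers come from a functional assay on the whole organism (strain STD-dd) with Mus musculus as the target, in the maximal electroshock model, with a stated time of 2 h; on this read-out higher numbers stand for an effect only at larger amounts of compound and lower numbers for an effect already at smaller amounts. Within the data shown here, compound 2 stands at one end of the two numbers, with compound 1 as its only neighbour; the step of a 1.3-fold higher number from compound 1 to compound 2 (0.11 log units; within the scatter) lies within the scatter, so the two compounds are not separable on this read-out.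

The next compound, compound 3 `CN1CCN(S(=O)(=O)Cc2noc3ccc(Br)cc23)CC1`, differs from compound 2 in one place: 4-methylpiperazin-1-yl in place of ethylamino on a sulfonyl sulfur. Among the measured compounds shown here, the only measured step, a 1.3-fold higher number from compound 1 to compound 2 (0.11 log units; within the scatter), concerns a smaller substitution on the sulfonamide nitrogen and was within the scatter. For the measured compounds named here, no measured step covers a change of this size at the sulfonyl sulfur, so the expectation rests on that single step alone: no step beyond the scatter, with the range widened to admit a shift in either direction.

Compound 3 is therefore expected at 24 mg/kg, between 10 mg/kg and 60 mg/kg. The step this expectation implies is a 1.3-fold higher number from compound 2 to compound 3 (0.12 log units; within the scatter).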

Compound 3, dose for half-maximal effect: 88 mg/kg
Compound 3: the middle estimate sits 3.7-fold (0.56 log units) below what was measured, and the stated range ends below it.
By their numbers in this assay, from the lowest: compounds 1 and 2 (each within the scatter of the next); then compound 3.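

In this assay, the group on the sulfonyl sulfur can shift the number beyond the scatter: 4-methylpiperazin-1-yl in place of ethylamino gives a 4.9-fold higher number from compound 2 to compound 3 (0.69 log units; beyond the scatter), and 4-methylpiperazin-1-yl in place of amino gives a 6.3-fold higher number from compound 1 to compound 3 (0.80 log units; beyond the scatter). The earlier ethyl change on the sulfonamide nitrogen gave no separation, so this place is not indifferent to every replacement, and the shift seen here is towards effect only at larger amounts of compound. In the step from ethylamino, group size, the six-membered non-aromatic ring and the hydrogen-bond donor all change together, and nothing measured here bears on which of them matters.

Open, on these data alone, is whether piperidin-1-yl or morpholin-4-yl would stand with compound 3 or with compound 1 and compound 2. Also open, as far as these compounds go, is where an open-chain dimethylamino group would fall.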